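A few compounds are considered here, and "the series" means these few. Any claim that something is new, unique, unknown or untested is made for them only; others in the source may bear on it.

Three compounds were measured in a functional assay on MGC-803 cells (Homo sapiens) for inhibition, read by MTT assay, with a stated time of 72 h, tested at 10 uM; on this read-out lower numbers stand for less inhibition of growth and higher numbers for more inhibition of growth at the one concentration tested:

compound 1 `O=C(/C=C/c1ccc(Oc2ncnc3ccc(Cl)cc23)cc1)/C=C/c1c(Cl)cccc1Cl`: 61.7%
compound 2 `O=C(/C=C/c1ccc(Oc2ncnc3ccc(Cl)cc23)cc1)/C=C/c1cccc(Cl)c1Cl`: 68.5%
compound 3 `O=C(/C=C/c1ccccc1Oc1ncnc2ccc(Cl)cc12)/C=C/c1cccc(Cl)c1Cl`: 76.5%

Compound 2 and compound 1 differ in one place, (2,6-dichlorophenyl in place of 2,3-dichlorophenyl on a double-bonded chain carbon bound to a double-bonded chain carbon), and that change gave a number 6.8 percentage points lower from compound 2 to compound 1 (within the scatter). Compound 3 has a different core from compound 2; the difference between the two cores is not broken down here. Compound 3 stands highest of the three numbers, yet only its gap to compound 1 lies beyond the scatter.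

Compound 4 `O=C(/C=C/c1ccccc1Oc1ncnc2ccc(Cl)cc12)/C=C/c1c(Cl)cccc1Cl` has not been measured. It differs from compound 3 by 2,6-dichlorophenyl in place of 2,3-dichlorophenyl on a double-bonded chain carbon bound to a double-bonded chain carbon, the same change at the same place as from compound 2 to compound 1. Because a number 6.8 percentage points lower from compound 2 to compound 1 (within the scatter) was small, a step of similar size is expected, a number 6.5 percentage points lower from compound 3 to compound 4 (within the scatter). Compound 4 is therefore estimated at 70%, between 56% and 82%.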

Compound 4, percent growth inhibition at one concentration: 69.3%
For compound 4 the middle estimate is 0.7 percentage points above the measured one, within the range that was stated.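

In this assay, 2,6-dichlorophenyl in place of 2,3-dichlorophenyl gave a number 7.2 percentage points lower from compound 3 to compound 4 (within the scatter). Set beside the earlier step, the change behaved alike on the two cores: the same change on two cores in this assay, a number 6.8 percentage points lower (within the scatter) from compound 2 to compound 1 and a number 7.2 percentage points lower (within the scatter) from compound 3 to compound 4, 0.4 percentage points apart, within the scatter of two such steps. This shows that the size of the step carried over between these two cores, but each step lies within the scatter on its own, so it does not show that the change has a real effect on growth inhibition, and two cores cannot establish that it would carry over to a third.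

The compounds shown leave open whether the same step would appear with an amine or a carboxylic acid in place of the two chlorines. They also leave open what a longer chain between the carbonyl and the dichlorophenyl would do.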